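Compound 4: hydroxy in place of the amino arm of compound 1

The source may report more compounds than this note shows. Statements on the series, on what has been measured and on what is new or still open speak of the compounds shown alone.

Compound 1 `COc1ccc(/C=C\c2cc(OC)c(OC)c(OC)c2)cc1OCc1ccc(CN[C@H](C(=O)O)[C@H](C)O)cc1` was tested in an ADME assay on HEK293 cells (Homo sapiens) for cytotoxicity, read by CCK-8 assay, with a stated time of 48 h; a lower number here means a stronger inhibitor, a higher number a weaker inhibitor. In this assay compound 1 gives only a limit, > 50000 nM. Compound 3 `COc1ccc(/C=C\c2cc(OC)c(OC)c(OC)c2)cc1OCc1ccc(CNCCO)cc1` likewise gives only a limit in this assay, > 50000 nM. Compound 2 `COc1ccc(/C=C\c2cc(OC)c(OC)c(OC)c2)cc1OCc1ccc(CN2CC[C@@H](C(=O)O)C2)cc1` gives 27000 nM in this assay, a change of an at least 1.8-fold lower number from compound 1 to compound 2 (0.26 log units; that floor lies within the scatter) and of an at least 1.8-fold higher number from compound 2 to compound 3 (0.26 log units; that floor lies within the scatter), while the step that the two limits leave unreadable from compound 1 to compound 3 cannot be sized because two of the three values sit at the limit of > 50000 nM in this assay, at which 2 of the 3 values shown sit. Compound 4 `COc1ccc(/C=C\c2cc(OC)c(OC)c(OC)c2)cc1OCc1ccc(CO)cc1` differs from compound 1 by hydroxy in place of (1-carboxy-2-hydroxypropyl)amino on a saturated chain carbon bound to an aromatic carbon. The shorter change from compound 1 to compound 3 already left the limit unchanged, so compound 4 is expected to stay at a limit as well, estimated at 60000 nM with a range of 25000 nM to 150000 nM. This estimate means an expected step that the limit leaves unreadable from compound 1 to compound 4, nothing beyond the scatter.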

Compound 4, half-maximal inhibitory concentration: 37000 nM
Compound 4: the middle estimate sits 1.6-fold (0.21 log units) above what was measured; the measured number falls inside the stated range.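

With hydroxy on the saturated chain carbon bound to an aromatic carbon, the loss of the whole amino arm gives an at least 1.3-fold lower number from compound 1 to compound 4 (0.13 log units; that floor lies within the scatter) in this assay, and the shorter comparison gives an at least 1.3-fold lower number from compound 3 to compound 4 (0.13 log units; that floor lies within the scatter). Both are floors only. The step to the one other arm with a measured number is a 1.4-fold higher number from compound 2 to compound 4 (0.14 log units; within the scatter), so this position has so far shown no separation between hydroxy and 3-carboxypyrrolidin-1-yl, and neither the amine nitrogen nor the carboxylic acid is needed for a number short of the limit.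

From the compounds shown here alone, whether a methoxy group, a primary amine or a longer chain at this carbon would move the number beyond the scatter stays open. How far compound 1 and compound 3 truly lie from the others also cannot be read: the limit of > 50000 nM in this assay, at which 2 of the 4 values shown sit.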